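What an iodo group may do to compound 2

The compounds below may be only part of what the source reports. "The series", "measured", "known", "first", "only" and "open" are said of these compounds alone.

Measured in a functional assay on A549 cells (Homo sapiens) for antiproliferative activity, read by sulforhodamine B assay, with a stated time of 72 h; on this read-out lower numbers stand for stronger inhibition and higher numbers for weaker inhibition:
compound 1 `COc1ccc(/C=C2\CCC=CC2=O)cc1OC`: 4680 nM
compound 2 `COc1cc(/C=C2\CCC=CC2=O)cc(OC)c1OC`: 4250 nM
compound 3 `COc1cc(/C=C2\CCC=CC2=O)cc(OC)c1O`: 1540 nM

Compound 2 stands with compound 1 in the upper part of these numbers, well clear of compound 3. The next compound, compound 4 `COc1cc(/C=C2\CCC=C(I)C2=O)cc(OC)c1OC`, keeps the core of compound 2 but carries iodo in place of hydrogen on a double-bonded ring carbon.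

Neither measured step touches that carbon, since both changes sit on the aromatic ring. They therefore give only a rough sense of scale. Adding a methoxy gave a 1.1-fold lower number from compound 1 to compound 2 (0.04 log units; within the scatter), while replacing a methyl on an oxygen with hydrogen gave a 2.8-fold lower number from compound 2 to compound 3 (0.44 log units; beyond the scatter). Going by the values given here, no compound here shows a change at the double-bonded ring carbon, so the direction remains an open question and the range must stay wide. Going by the size of those two steps, a small or modest change is expected, with a slight lean towards a lower number. The expected step is a 1.7-fold lower number from compound 2 to compound 4 (0.23 log units; within the scatter). Compound 4 is estimated at 2500 nM, with an expected range from 700 nM to 8000 nM.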

Compound 4, half-maximal inhibitory concentration: 4860 nM
For compound 4 the middle estimate is 1.9-fold (0.29 log units) below the measured one; measured number inside the range.
By their numbers in this assay, from the lowest: compound 3; then compounds 2, 1 and 4 (each within the scatter of the next).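

In this assay, putting iodo in place of hydrogen on a double-bonded ring carbon gives a 1.1-fold higher number from compound 2 to compound 4 (0.06 log units; within the scatter), a step that cannot be told apart from the ordinary spread of repeated measurements. Going by these compounds alone, the earlier steps changed only groups on the aromatic ring, so this is the first reading at this carbon of the six-membered non-aromatic ring, and it shows that, on the core of compound 2, this position can carry an iodine atom with no measurable change in the number. Nothing shown here offers an explanation for this result.

As far as these compounds go, a single replacement at one carbon says little about the position as a whole, and whether a methyl group, an amine or a carboxylic acid at the same carbon would leave the number equally unchanged remains open. Within the data shown here, it is also unknown whether iodo at this carbon would behave the same way on compound 3, the one compound here whose number stands clearly apart from that of compound 2.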